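A few compounds are considered here, and "the series" means these few. Any claim that something is new, unique, unknown or untested is made for them only; others in the source may bear on it.

Compound 1, `COc1cc(C(=O)/C=C/c2cc(OC)c(OC)cc2OC)ccc1O`: in a functional assay on HeLa cells (Homo sapiens) for inhibition, read by MTT assay, with a stated time of 72 h (on this read-out lower numbers stand for stronger inhibition and higher numbers for weaker inhibition), compound 1 gives > 150000 nM, a limit of the assay rather than a number.
Compound 2, `COc1cc(OC)c(OC)cc1/C=C/C(=O)c1ccc([N+](=O)[O-])cc1`: in this assay compound 2 gives > 150000 nM, likewise a limit of the assay and not a number.

Compound 2 therefore stands at the edge of what this assay can report, and it is not alone there, since both values shown sit at that same limit (the limit of > 150000 nM in this assay, at which 2 of the 2 values shown sit). For the measured compounds named here, no step between two measured compounds is available in this set; of compounds 1 and 2 the two values show only that each is a limit, so nothing can be said about an order between them.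

The unmeasured compound 3, `COc1cc(OC)c(OC)cc1/C=C/C(=O)c1ccccc1`, differs from compound 2 in one place: hydrogen in place of nitro on an aromatic carbon. Going by the values given here, with compound 2 at the limit of this assay the limit of > 150000 nM in this assay, at which 2 of the 2 values shown sit, and no measured step to lean on, the expected step that the limit leaves unreadable from compound 2 to compound 3 is none beyond the scatter, and compound 3 is expected to remain at or near the limit. For compound 3 in this assay the estimate is 200000 nM, with a range from 50000 nM to 800000 nM.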

Compound 3, half-maximal inhibitory concentration: > 150000 nM
Compound 3 ended at the assay's limit; the forecaster's own chance of this, stated with the estimate: 75%; the middle value does not contradict the limit.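

Compound 2 and compound 3 both stand at a limit of this assay rather than at a number, so no step can be read for the change from nitro to hydrogen: the limit of > 150000 nM in this assay, at which 3 of the 3 values shown sit. The compounds shown leave open how strongly any of them inhibits in this assay, and whether their order differs at all.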